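Swapping the imidazole for a pyridine on the shared core

This account rests on a few compounds, and the source may have more. Where it says the series, first, only, none or still open, it means among the compounds named here.

Measured compounds and their values:
- Compound 1, `Nc1nc(-c2ccc(C(F)F)o2)nc2sc(Cc3ccccc3)cc12`, gives 3000 nM in a functional assay on CHO-K1 cells for antagonist activity at adenosine receptor A1 (Homo sapiens), read by a beta-galactosidase reporter and cAMP accumulation, with stated times of 15 min and 6 h; a higher number here means a weaker inhibitor, a lower number a stronger inhibitor.
- Compound 2, `Nc1nc(-c2ncco2)nc2sc(Cc3ccccc3)cc12`, gives 310 nM in this assay.
- Compound 3, `Cn1cnc(-c2nc(N)c3cc(Cc4ccccc4)sc3n2)c1`, gives 2330 nM in this assay.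

Compound 3 stands second highest of the three numbers. Its nearest neighbour is compound 1, and that pair lies within the scatter: a 1.3-fold lower number from compound 1 to compound 3 (0.11 log units; within the scatter). Its furthest is compound 2: a 7.5-fold higher number from compound 2 to compound 3 (0.88 log units; beyond the scatter), a modest gap beyond the scatter.

Compound 4, `Nc1nc(-c2ccncc2)nc2sc(Cc3ccccc3)cc12`, differs from compound 3 at one position: pyridin-4-yl in place of 1-methyl-1H-imidazol-4-yl on an aromatic carbon.

For the measured compounds named here, no measured step replaces a five-membered ring with a six-membered one, so none bears directly on this change. The steps that do touch the same position show what swapping one small aromatic ring for another can do here: a 9.7-fold lower number from compound 1 to compound 2 (0.99 log units; beyond the scatter) and a 7.5-fold higher number from compound 2 to compound 3 (0.88 log units; beyond the scatter) are both modest, while a 1.3-fold lower number from compound 1 to compound 3 (0.11 log units; within the scatter) is within the scatter. The most reasonable expectation is therefore a step of modest size at most, with the direction uncertain, expressed as a 1.6-fold lower number from compound 3 to compound 4 (0.19 log units; within the scatter).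

Compound 4 is expected to give about 1500 nM in this assay, with a likely range from 400 nM to 6000 nM.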

Compound 4, inhibition constant: 812 nM
For compound 4 the middle estimate is 1.8-fold (0.27 log units) above the measured one; the measured number falls inside the stated range.
By their numbers in this assay, from the lowest: compound 2; then compound 4; then compounds 3 and 1 (each within the scatter of the next).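

A six-membered aromatic ring is tolerated at this position on the shared core: in this assay there is a 2.9-fold lower number from compound 3 to compound 4 (0.46 log units; beyond the scatter) when pyridin-4-yl enters and 1-methyl-1H-imidazol-4-yl leaves. The new ring lands in the middle of the series, with a 3.7-fold lower number from compound 1 to compound 4 (0.57 log units; beyond the scatter) against 5-(difluoromethyl)furan-2-yl and a 2.6-fold higher number from compound 2 to compound 4 (0.42 log units; beyond the scatter) against 1,3-oxazol-2-yl, and both of these steps lie beyond the scatter. No measurement shown here explains why these rings differ from one another.

Ring size and the number of ring hetero atoms change together in the step from the imidazole to the pyridine, so that step alone cannot separate the two, and a phenyl ring, which has no ring nitrogen, would be the natural comparison. As far as these compounds go, whether the place of the ring nitrogen matters also stays open, as would be tested by pyridin-3-yl or pyridin-2-yl, and so does the effect of adding an amine or a methoxy group to the pyridine ring.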